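The compounds below may be only part of what the source reports. "The series", "measured", "known", "first", "only" and "open" are said of these compounds alone.

In a functional assay on A549 cells (Homo sapiens) for inhibition, read by MTT assay, with a stated time of 48 h, tested at 10 uM (on this read-out higher numbers stand for more inhibition of growth at the one concentration tested and lower numbers for less inhibition of growth), compound 1 `O=C(/C=C/c1ccc(OCc2cn(Cc3cccc(F)c3)nn2)cc1)c1ccc(Br)cc1` gives 37%, while compound 2 `O=C(/C=C/c1ccc(OCc2cn(Cc3ccc(Br)cc3)nn2)cc1)c1ccc([N+](=O)[O-])cc1` gives 18%. Compound 2 thus stands lowest of the two numbers, with compound 1 lying beyond the scatter above it. Compound 3 `O=C(/C=C/c1ccc(OCc2cn(Cc3cccc(F)c3)nn2)cc1)c1ccc([N+](=O)[O-])cc1` differs from compound 2 by 3-fluorophenyl in place of 4-bromophenyl on a saturated chain carbon bound to an aromatic nitrogen. Among the measured compounds shown here, compound 1 carries the same 3-fluorobenzyl group but differs from compound 3 elsewhere as well, so no directly comparable step is known. In this assay a step within the scatter, if anything slightly upward, is expected, namely a number 6 percentage points higher from compound 2 to compound 3 (within the scatter). Compound 3 is therefore estimated at 24%, within a range from 8% to 42%.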

Compound 3, percent growth inhibition at one concentration: 33%
Compound 3: the middle estimate sits 9 percentage points below what was measured; low and high end bracket the measured number.
By their numbers in this assay, from the lowest: compound 2; then compounds 3 and 1 (each within the scatter of the next).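

With the nitro group held constant, 3-fluorophenyl in place of 4-bromophenyl on a saturated chain carbon bound to an aromatic nitrogen gives a number 15 percentage points higher from compound 2 to compound 3 (beyond the scatter) in this assay, so this position can alter the read-out. With the 3-fluorobenzyl group held constant, nitro in place of bromo on an aromatic carbon gives a number 4 percentage points lower from compound 1 to compound 3 (within the scatter), so these two groups are not told apart here. No available evidence explains the step from 4-bromobenzyl to 3-fluorobenzyl. From the compounds shown here alone, whether 3-bromophenyl or 4-fluorophenyl would side with 3-fluorophenyl or with 4-bromophenyl remains open. Also open, going by these compounds, is how an amine on that aromatic carbon would compare with nitro and bromo.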